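A few compounds are considered here, and "the series" means these few. Any claim that something is new, unique, unknown or untested is made for them only; others in the source may bear on it.

Values in a functional assay on HepG2 cells (Homo sapiens) for antiproliferative activity, read by MTT assay, with a stated time of 48 h; a lower number here means a stronger inhibitor, a higher number a weaker inhibitor:
- compound 1 `CC(=O)N1N=C(c2ccc3ccccc3c2)OC1c1ccccc1Br`: 3.98 ug/mL
- compound 2 `CC(=O)N1N=C(c2ccc3ccccc3c2)OC1c1ccccc1Cl`: 4.32 ug/mL
- compound 3 `CC(=O)N1N=C(c2ccc3ccccc3c2)OC1c1ccc(Cl)cc1`: 1.88 ug/mL

Compound 3 has the lowest number of the three. The next change gives compound 4 `CC(=O)N1N=C(c2ccc3ccccc3c2)OC1c1cccc(F)c1`, with 3-fluorophenyl in place of 4-chlorophenyl on a saturated ring carbon. Two measured steps change the group at this place, a 2.1-fold lower number from compound 1 to compound 3 (0.33 log units; beyond the scatter) and a 2.3-fold lower number from compound 2 to compound 3 (0.36 log units; beyond the scatter), and both are modest. The halogen swap, a 1.1-fold higher number from compound 1 to compound 2 (0.04 log units; within the scatter), stays within the scatter. Within the data shown here, no measured compound carries a 3-fluorophenyl group, so the read-across is loose. A modest move towards a higher number is expected, with the estimated step being a 1.6-fold higher number from compound 3 to compound 4 (0.20 log units; within the scatter). The expected value for compound 4 is 3 ug/mL, with an estimated range of 1.5 ug/mL to 6 ug/mL.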

Compound 4, half-maximal inhibitory concentration: 1.86 ug/mL
Estimate against measurement, compound 4: 1.6-fold (0.21 log units) above; low and high end bracket the measured number.
By their numbers in this assay, from the lowest: compounds 4 and 3 (each within the scatter of the next); then compounds 1 and 2 (each within the scatter of the next).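

In this assay a second group at this saturated ring carbon, 3-fluorophenyl, cannot be told apart from 4-chlorophenyl (a 1.0-fold lower number from compound 3 to compound 4 (0.00 log units; within the scatter)). The gap to the two other groups therefore recurs with a different halogen at a different place on the phenyl ring, modest against 2-chlorophenyl (a 2.3-fold lower number from compound 2 to compound 4 (0.37 log units; beyond the scatter)) and against 2-bromophenyl (a 2.1-fold lower number from compound 1 to compound 4 (0.33 log units; beyond the scatter)). No measured evidence accounts for these steps.

Halogen and its place on the phenyl ring still change together between compound 3 and compound 4, so 4-fluorophenyl or 3-chlorophenyl would be needed to separate them. Going by these compounds, whether a non-halogen group, such as methoxy or an amine, fits at this carbon remains open.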